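Indole nitrogen substituents and BV-2 cytotoxicity

The source may hold more compounds than are shown below. What is called first, only, known or untested is meant among the compounds shown, and "the series" means these compounds.

Measured so far:
- compound 1 `O=C1COCCN1c1ccc(/N=C\c2c[nH]c3ccccc23)cc1`: 105%
- compound 2 `Cc1ccc(S(=O)(=O)n2cc(/C=N\c3ccc(N4CCOCC4=O)cc3)c3ccccc32)cc1`: 92.1%
- compound 3 `O=C1COCCN1c1ccc(/N=C\c2cn(Cc3ccccc3)c3ccccc23)cc1`: 89.3%

In an ADME assay on BV-2 cells (Mus musculus) for cytotoxicity, read by MTT assay, with a stated time of 48 h, tested at 1 uM (a higher number here means a weaker effect of the compound at the concentration tested, a lower number a stronger effect), compound 1 gives 105% with a hydrogen on the aromatic nitrogen of the shared core. Compound 2 carries (4-methylphenyl)sulfonyl there and sits lower, a number 12.9 percentage points lower from compound 1 to compound 2 (beyond the scatter); compound 3 carries benzyl and also sits lower than compound 1, a number 15.7 percentage points lower from compound 1 to compound 3 (beyond the scatter). Between compound 2 and compound 3 the gap is small, a number 2.8 percentage points lower from compound 2 to compound 3 (within the scatter), so on the numbers shown compound 2 stands apart from compound 1 but not from compound 3.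

Compound 4 `O=C1COCCN1c1ccc(/N=C\c2cn(Cc3ccc(F)cc3)c3ccccc23)cc1` is not yet measured. Its change from compound 2 is 4-fluorobenzyl in place of (4-methylphenyl)sulfonyl on an aromatic nitrogen. Going by the values given here, the only measured step that bears on it is the exchange of (4-methylphenyl)sulfonyl for benzyl, a number 2.8 percentage points lower from compound 2 to compound 3 (within the scatter), which stayed within the scatter; no step with a fluorine-bearing group exists in this set. Compound 4 is therefore expected to lie close to compound 2 in this assay, with a step of about a number 4.1 percentage points lower from compound 2 to compound 4 (within the scatter), not beyond the scatter. The estimate for compound 4 is 88%, in the range 76% to 100%.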

Compound 4, a percentage reported as activity, at one concentration (the size of the read-out at that concentration, not a potency): 87.9%
Compound 4: middle estimate off by 0.1 percentage points, on the high side; low and high end bracket the measured number.
By their numbers in this assay, from the lowest: compounds 4, 3 and 2 (each within the scatter of the next); then compound 1.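

In this assay, the aromatic nitrogen tolerates a fluorine on the benzyl ring without a readable shift (a number 1.4 percentage points lower from compound 3 to compound 4 (within the scatter)), and the exchange of (4-methylphenyl)sulfonyl for 4-fluorobenzyl also stays inside the scatter (a number 4.2 percentage points lower from compound 2 to compound 4 (within the scatter)). Against the hydrogen of compound 1, the new group gives the largest printed step of the series (a number 17.1 percentage points lower from compound 1 to compound 4 (beyond the scatter)), though it cannot be separated from the benzyl of compound 3, so compound 2, compound 3 and compound 4 form one group apart from compound 1. No measurement at hand gives a reason for these steps.

On these data alone, it remains open whether a methyl, a longer alkyl chain, or a benzyl carrying an amine or a carboxylic acid on this nitrogen would fall with that group or with compound 1. A single concentration also leaves open how these compounds behave at higher concentrations.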